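The source may hold more compounds than are shown below. What is called first, only, known or untested is meant among the compounds shown, and "the series" means these compounds.

In a functional assay on A549 cells (Homo sapiens) for cytotoxicity, read by MTT assay, with a stated time of 72 h (a higher number here means a weaker inhibitor, a lower number a stronger inhibitor), compound 1 `COc1cccc(/C=C2\CCC/C(=C\c3ccc(OC)c(OC)c3)C2=O)c1` gives 6700 nM. Compound 2 `COc1ccc(/C=C2\CCC/C(=C\c3ccc(OC)c(OC)c3)C2=O)cc1` reaches only a limit of the assay, > 20000 nM. Compound 3 `COc1ccc(/C=C2\CCC/C(=C\c3ccc(OC)c(OC)c3)C2=O)cc1OC` gives 8500 nM, within the scatter of the value for compound 1. Compound 4 `COc1ccc(/C=C2\CCC/C(=C\c3cc(OC)c(OC)c(OC)c3)C2=O)cc1OC` differs from compound 3 by one change, methoxy in place of hydrogen on an aromatic carbon. The same kind of change has been measured twice: a 1.3-fold higher number from compound 1 to compound 3 (0.10 log units; within the scatter), and an at least 2.3-fold lower number from compound 2 to compound 3 (0.37 log units; beyond the scatter). The second of these starts from a limit, so the first, which joins two numbers, is the closer guide. No step beyond the scatter is therefore expected in this assay. For compound 4 the estimated value is 7500 nM, with an expected range from 3000 nM to 19000 nM.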

Compound 4, half-maximal inhibitory concentration: 2900 nM
For compound 4 the middle estimate is 2.6-fold (0.41 log units) above the measured one; measured number outside the range, below it.
By their numbers in this assay, from the lowest: compound 4; then compounds 1 and 3 (each within the scatter of the next). At a limit, above all of these: compound 2.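

In this assay, the step of a 2.9-fold lower number from compound 3 to compound 4 (0.47 log units; beyond the scatter) shows that methoxy in place of hydrogen can go beyond the scatter when it enters on an aromatic carbon ortho to a methoxy group and meta to a large group. Elsewhere the same kind of change gave a 1.3-fold higher number from compound 1 to compound 3 (0.10 log units; within the scatter), so among these compounds its size differs with the place. Nothing given here accounts for the step.

From the compounds shown here alone, it remains open whether the gain belongs to methoxy itself or would also appear with a hydroxy group, an amine or a longer chain such as ethoxy on this carbon.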